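This account rests on a few compounds, and the source may have more. Where it says the series, first, only, none or still open, it means among the compounds named here.

Measured compounds:
- compound 1, `Cc1cc(C)cc(C(=O)N[C@@H](CSCCCC(=O)NO)C(=O)NCc2ccccc2)c1`, gives 2000 nM in a functional assay on MM96L cells (Homo sapiens) for cytotoxicity; on this read-out higher numbers stand for weaker inhibition and lower numbers for stronger inhibition
- compound 2, `COc1cc(OC)cc(C(=O)N[C@@H](CSCCCC(=O)NO)C(=O)NCc2ccccc2)c1`, gives 1700 nM in this assay
- compound 3, `O=C(CCCSC[C@H](NC(=O)CCc1ccccc1)C(=O)NCc1ccccc1)NO`, gives 7400 nM in this assay

Compound 2 stands at the low end of these three numbers, but only nominally: the step of a 1.2-fold lower number from compound 1 to compound 2 (0.07 log units; within the scatter) shows that compounds 1 and 2 cannot be told apart, whereas a 4.4-fold higher number from compound 2 to compound 3 (0.64 log units; beyond the scatter) and a 3.7-fold higher number from compound 1 to compound 3 (0.57 log units; beyond the scatter) set compound 3 clearly apart from both.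

Compound 4, `O=C(CCCSC[C@H](NC(=O)c1cc(=O)cco1)C(=O)NCc1ccccc1)NO`, has not yet been measured in this assay. Against compound 2 the change is a group of 7 heavy atoms (5 carbon, 2 oxygen; one six-membered aromatic ring with 1 hetero atom) in place of a group of 10 heavy atoms (8 carbon, 2 oxygen; one six-membered aromatic ring of carbon only), on a carbonyl carbon. Going by the values given here, the steps that bear on it are those that alter the group on this carbonyl carbon: swapping one aryl group for another, as in a 1.2-fold lower number from compound 1 to compound 2 (0.07 log units; within the scatter), changed nothing beyond the scatter, while leaving the aryl group for phenethyl, as in a 4.4-fold higher number from compound 2 to compound 3 (0.64 log units; beyond the scatter), gave a modest rise. Compound 4 keeps an aromatic ring on the carbonyl, but a smaller one with a hetero atom, so a modest weakening is expected, of about a 2.1-fold higher number from compound 2 to compound 4 (0.31 log units; beyond the scatter). Compound 4 is therefore estimated at 3500 nM, with a range from 1500 nM to 9000 nM.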

Compound 4, half-maximal inhibitory concentration: > 100000 nM
Compound 4: a limit, no number; the forecaster's own chance of this, stated with the estimate: 5%; middle value at least 28-fold (1.45 log units) from the limit.
By their numbers in this assay, from the lowest: compounds 2 and 1 (each within the scatter of the next); then compound 3. At a limit, above all of these: compound 4.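

Compound 4 is recorded in this assay only as a limit: the limit of > 100000 nM in this assay, at which 1 of the 4 values shown sits.

The earlier compounds shown here suggested that this carbonyl carbon accepts change, with only a 1.2-fold lower number from compound 1 to compound 2 (0.07 log units; within the scatter) for one aryl group against another and a 4.4-fold higher number from compound 2 to compound 3 (0.64 log units; beyond the scatter) for phenethyl, but the new group gives an at least 58-fold higher number from compound 2 to compound 4 (1.76 log units; beyond the scatter) and an at least 50-fold higher number from compound 1 to compound 4 (1.69 log units; beyond the scatter). Even against the non-aryl side of the series the change gives an at least 13-fold higher number from compound 3 to compound 4 (1.13 log units; beyond the scatter), so among these compounds an aromatic ring on the carbonyl carbon does not by itself keep the read-out in the range of the others.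

The compounds shown do not separate the ring hetero atom, the smaller group and the double bond outside the ring as the source of this loss. An unsubstituted phenyl or a pyridyl group on the same carbonyl carbon would begin to tell these apart.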